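Adding an Amino Group: From Compound 2 to Compound 4

This account rests on a few compounds, and the source may have more. Where it says the series, first, only, none or still open, it means among the compounds named here.

Compound 1 `ClCc1ccccc1Cn1cnc2c(Cl)nc(Cl)nc21`: 510 nM
Compound 2 `ClCc1ccccc1Cn1cnc2c(Cl)ncnc21`: 3540 nM
Compound 3 `ClCc1cccc(Cn2cnc3ncnc(Cl)c32)c1`: 3230 nM

These three compounds were tested in a functional assay on OVCAR-3 cells (Homo sapiens) for cytotoxicity, read by sulforhodamine B assay, with a stated time of 48 h; a lower number here means a stronger inhibitor of growth, a higher number a weaker inhibitor of growth. Compound 2 gives the highest number of the three in this assay. The value of compound 3 lies within the scatter of that of compound 2, so the two cannot be told apart, while compound 1 gives a clearly lower number. For the measured compounds named here, the one step that links two compounds differing in a single place is a 6.9-fold higher number from compound 1 to compound 2 (0.84 log units; beyond the scatter), a hydrogen taking the place of a chloro group on an aromatic carbon.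

Compound 4 `Nc1nc(Cl)c2ncn(Cc3ccccc3CCl)c2n1` has not yet been measured. It differs from compound 2 by amino in place of hydrogen on an aromatic carbon, the amino group sitting on an aromatic carbon of the six-membered aromatic ring with two nitrogen atoms, between two ring nitrogen atoms, meta to a chloro group. Going by the values given here, no measured step puts an amino group at this place, so nothing bears on the change directly. Among the compounds with values here, the only step available, a 6.9-fold higher number from compound 1 to compound 2 (0.84 log units; beyond the scatter), shows that a substituent on this core can move the number well beyond the scatter, but it concerns a chloro group rather than an amino group. A modest move toward a lower number is therefore expected, a 2.4-fold lower number from compound 2 to compound 4 (0.37 log units; beyond the scatter), with wide uncertainty. For compound 4 the estimated value in this assay is 1500 nM, expected to fall within the range from 400 nM to 5000 nM.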

Compound 4, concentration for total growth inhibition: 20000 nM
The estimate for compound 4 lay 13-fold (1.12 log units) below the measured number, and the stated range ends below it.
By their numbers in this assay, from the lowest: compound 1; then compounds 3 and 2 (each within the scatter of the next); then compound 4.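

In this assay, an amino group on the aromatic carbon between two ring nitrogen atoms gives a 5.6-fold higher number from compound 2 to compound 4 (0.75 log units; beyond the scatter), so adding a group at this place does not by itself bring the number down. For the compounds shown here, the earlier step, a 6.9-fold higher number from compound 1 to compound 2 (0.84 log units; beyond the scatter), showed only that losing a chloro group from this carbon raises the number, whereas the new comparison, a 39-fold higher number from compound 1 to compound 4 (1.59 log units; beyond the scatter), sets amino directly against chloro and shows that the identity of the group sets the direction: measured against hydrogen, chloro goes with a lower number and amino with a higher one. Nothing measured on these compounds accounts for that difference between the two groups.

On these data alone, it remains open whether a methylamino group, a dimethylamino group, a methoxy group or a fluoro group on this same carbon would give a number closer to that of the chloro compound or that of the amino compound. As far as these compounds go, it is also open whether an amino group at this place would shift the number in the same direction on the core of compound 3, where the chloromethyl group sits elsewhere on the benzyl ring.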